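Ring methyl and thiocarbonyl amine changes in a cytotoxicity series

The source may hold more compounds than are shown below. What is called first, only, known or untested is meant among the compounds shown, and "the series" means these compounds.

Measured compounds:
compound 1 `N/C(=N\NC(=S)N1CCOCC1)c1ccccn1` with 78.1%
compound 2 `Cc1ccnc(/C(N)=N/NC(=S)N2CCOCC2)c1` with 8.16%
compound 3 `N/C(=N\NC(=S)N1CCSCC1)c1ccccn1` with 72.6%

In a functional assay on MCF7 cells (Homo sapiens) for cytotoxicity, read by MTT assay, with a stated time of 72 h, tested at 30 uM (on this read-out lower numbers stand for less inhibition of growth and higher numbers for more inhibition of growth at the one concentration tested), compound 1 gives 78.1%, the highest of the three numbers. The step of a number 5.5 percentage points lower from compound 1 to compound 3 (within the scatter) lies within the scatter, whereas a number 69.9 percentage points lower from compound 1 to compound 2 (beyond the scatter) is large.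

Compound 4 `Cc1cccc(/C(N)=N/NC(=S)N2CCOCC2)n1` differs from compound 1 by methyl in place of hydrogen on an aromatic carbon. Among the compounds with values here, the only measured step that bears on this is a number 69.9 percentage points lower from compound 1 to compound 2 (beyond the scatter), also a methyl entering an aromatic carbon of the same ring, though at another carbon; it was large and downward. Within the data shown here, a downward step in this assay is therefore expected for compound 4, with a wide range, as the single comparison sits at a different ring carbon. The estimate for compound 4 is 35%, between 5% and 75%, meaning an expected step of a number 43.1 percentage points lower from compound 1 to compound 4 (beyond the scatter).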

Compound 4, percent growth inhibition at one concentration: 57.8%
Compound 4: the middle estimate sits 22.8 percentage points below what was measured; the range from low to high includes it.
By their numbers in this assay, from the lowest: compound 2; then compound 4; then compounds 3 and 1 (each within the scatter of the next).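

In this assay methyl next to the ring nitrogen gives a number 20.3 percentage points lower from compound 1 to compound 4 (beyond the scatter) and so costs some growth inhibition at this carbon. Set beside a number 69.9 percentage points lower from compound 1 to compound 2 (beyond the scatter) for methyl at another ring carbon, this shows that the size of the loss depends on which ring carbon carries the methyl. Nothing available explains this difference between the two carbons.

As far as these compounds go, whether the loss at this carbon is specific to methyl, or would also appear with ethyl or an amine, remains open. Also open, from the compounds shown here alone, is how this methyl would act with the thiomorpholin-4-yl group of compound 3.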